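The compounds below may be only part of what the source reports. "The series", "measured", "known", "first", "only" and "open" are said of these compounds alone.

Measured compounds in a functional assay on MDA-MB-231 cells (Homo sapiens) for inhibition, read by sulforhodamine B assay; on this read-out lower numbers stand for stronger inhibition and higher numbers for weaker inhibition:

Compound 1, `COC(=O)CC/C(C)=C/Cc1c(OC)c(C)c2c(c1OCC#CCN1CCN(C(c3ccccc3)c3ccccc3)CC1)C(=O)OC2`, comes out at > 50000 nM, which is a limit of the assay and not a number.
Compound 2, `COC(=O)CC/C(C)=C/Cc1c(OC)c(C)c2c(c1OCC#CCN1CCN(C(=O)C3COc4ccccc4O3)CC1)C(=O)OC2`, comes out at > 50000 nM, again a limit of the assay rather than a number.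
Compound 3, `COC(=O)CC/C(C)=C/Cc1c(OC)c(C)c2c(c1OCC#CCN1CCN(C(c3ccc(F)cc3)c3ccc(F)cc3)CC1)C(=O)OC2`, comes out at > 50000 nM, also a limit of the assay.

Compound 2 therefore stands nowhere in particular on the numbers shown: its value is only a limit, and the two other values shown are limits as well, so no order among these three compounds can be read off. The evidence amounts to the limit of > 50000 nM in this assay, at which 3 of the 3 values shown sit.

Compound 4, `COC(=O)CC/C(C)=C/Cc1c(OC)c(C)c2c(c1OCC#CCN1CCN(c3ccccc3OC)CC1)C(=O)OC2`, differs from compound 2 at the amine nitrogen in a ring of the six-membered non-aromatic ring with two nitrogen: 2-methoxyphenyl in place of (2,3-dihydro-1,4-benzodioxin-2-yl)carbonyl on an amine nitrogen in a ring. Going by the values given here, no measured step between two compounds is available, so the expected size of the step from compound 2 to compound 4 in this assay rests on the three limits alone, and the expectation is no step beyond the scatter, that is a step that the limit leaves unreadable from compound 2 to compound 4. The estimate for compound 4 in this assay is 60000 nM, with a range from 20000 nM to 200000 nM.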

Compound 4, half-maximal inhibitory concentration: > 50000 nM
Compound 4: no number, only a limit; the forecaster's own chance of this, stated with the estimate: 85%; the middle value is on the limit's open side.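

Going by these compounds alone, compound 2 and compound 4 both sit at a limit of the assay and not at a number, so no step between them can be read. The compounds shown leave open how strongly, if at all, any of them inhibits in this assay, and whether any group on this amine nitrogen would give a readable value.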